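A few compounds are considered here, and "the series" means these few. Any claim that something is new, unique, unknown or untested is made for them only; others in the source may bear on it.

Working notes on the series. All four compounds sit on a shared core: compound 1 `COc1ccc(CNC(=O)CSc2nc3ccc(NC(C)=O)cc3s2)cc1` and compound 2 `CC(=O)Nc1ccc2nc(SCC(=O)NCc3ccc(Cl)cc3)sc2c1` carry an acetamido group on that core, while compound 3 `COc1ccccc1C(=O)Nc1ccc2nc(SCC(=O)NCc3ccc(Cl)cc3)sc2c1` and the as yet unmeasured compound 4 `COc1ccc(CNC(=O)CSc2nc3ccc(NC(=O)c4ccccc4OC)cc3s2)cc1` carry a ((2-methoxyphenyl)carbonyl)amino group in its place. In a functional assay on MCF7 cells (Homo sapiens) for cytotoxicity, read by MTT assay, with a stated time of 48 h (on this read-out lower numbers stand for stronger inhibition and higher numbers for weaker inhibition), compound 1 gives 20500 nM, compound 2 gives 10200 nM and compound 3 gives 1100 nM.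

Two structural differences are counted among the measured compounds. The first, (methoxy in place of chloro on an aromatic carbon), measures as a 2.0-fold higher number from compound 2 to compound 1 (0.30 log units; within the scatter). For the measured compounds named here, the second, (2-methoxyphenyl in place of methyl on a carbonyl carbon), is what separates the core of compound 2 from the core of compound 3 and measures as a 9.3-fold lower number from compound 2 to compound 3 (0.97 log units; beyond the scatter); this is the only step here beyond the scatter, and compound 3 holds the lowest of the three numbers on that account.

Compound 4 differs from compound 3 by methoxy in place of chloro on an aromatic carbon. Going by the values given here, this is the same change as the one from compound 2 to compound 1: the group that leaves, the group that enters and the place are described in identical words. Among the compounds with values here, it has been observed once, on the acetamido core, and nothing among the measured compounds shows whether the larger amide alters its outcome. Within the data shown here, the step from compound 3 to compound 4 in this assay is therefore expected to be a 2.0-fold higher number from compound 3 to compound 4 (0.30 log units; within the scatter), because the single prior instance measured as a 2.0-fold higher number from compound 2 to compound 1 (0.30 log units; within the scatter). On that basis compound 4 is estimated at 2200 nM, with a plausible range from 1000 nM to 5000 nM.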

Compound 4, half-maximal inhibitory concentration: 9300 nM
The estimate for compound 4 lay 4.2-fold (0.63 log units) below the measured number, outside the stated range (above it).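

In this assay, methoxy in place of chloro measures as an 8.5-fold higher number from compound 3 to compound 4 (0.93 log units; beyond the scatter), so this change did not carry over at the same size from the acetamido core to the core bearing the ((2-methoxyphenyl)carbonyl)amino group: the same change on two cores in this assay, a 2.0-fold higher number (0.30 log units; within the scatter) from compound 2 to compound 1 and an 8.5-fold higher number (0.93 log units; beyond the scatter) from compound 3 to compound 4, 4.2-fold (0.62 log units) apart, beyond the scatter of two such steps. Read the other way round, 2-methoxyphenyl in place of methyl still lowers the number on the methoxy side, measuring as a 2.2-fold lower number from compound 1 to compound 4 (0.34 log units; beyond the scatter), but it does so by less than on the chloro side: the same change on two cores in this assay, a 9.3-fold lower number (0.97 log units; beyond the scatter) from compound 2 to compound 3 and a 2.2-fold lower number (0.34 log units; beyond the scatter) from compound 1 to compound 4, 4.2-fold (0.62 log units) apart, beyond the scatter of two such steps. Both gaps come from the same four compounds, so they amount to a single observation that the two changes do not add up here; it gives no cause and does not show how either change would behave on any other core.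

The compounds shown leave open whether the larger step on the chloro side is tied to chloro itself or would also appear with fluoro or methyl in that place on the benzyl group. They also leave open whether phenyl or 2-hydroxyphenyl on the carbonyl would follow 2-methoxyphenyl in the same way.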